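The source may hold more compounds than are shown below. What is called first, only, known or untested is meant among the compounds shown, and "the series" means these compounds.

Compound 2 `CCSC(=S)SCC(=O)c1ccc(OC)cc1` gives the lowest number of the three compounds in a functional assay on HeLa cells (Homo sapiens) for antiproliferative activity, read by resazurin assay; a lower number here means a stronger inhibitor, a higher number a weaker inhibitor: compound 2 gives 2510 nM. Compound 1 `CCSC(=S)SCC(=O)c1ccc(S(N)(=O)=O)cc1` gives 20000 nM, a step of an 8.0-fold lower number from compound 1 to compound 2 (0.90 log units; beyond the scatter), and compound 3 `CCSC(=S)SCC(=O)c1ccc(OC)cc1OC` gives 12600 nM, a step of a 5.0-fold higher number from compound 2 to compound 3 (0.70 log units; beyond the scatter). Compound 4 `COc1ccc(C(=O)CSC(C)=O)cc1` differs from compound 2 at the sulfur, (a group of 3 heavy atoms (2 carbon, 1 oxygen; no ring) in place of a group of 5 heavy atoms (3 carbon, 2 sulfur; no ring), on a sulfur). Both measured steps concern substituents on the aromatic ring, so neither bears on a change at the sulfur, and nothing measured shows what the group of 5 heavy atoms contributes. Compound 4 is therefore expected to give 10000 nM, within 2000 nM to 50000 nM, an estimated step of a 4.0-fold higher number from compound 2 to compound 4 (0.60 log units; beyond the scatter), with wide uncertainty.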

Compound 4, half-maximal inhibitory concentration: 25100 nM
Beside the measured number, compound 4's estimate is 2.5-fold (0.40 log units) below it, within the range that was stated.
By their numbers in this assay, from the lowest: compound 2; then compounds 3, 1 and 4 (each within the scatter of the next).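

Within the data shown here, the earlier compounds changed only substituents on the aromatic ring, so this is the first view of the group on the sulfur. In this assay, acetyl in place of the group of 5 heavy atoms gives a 10-fold higher number from compound 2 to compound 4 (1.00 log units; beyond the scatter), so this position also affects the antiproliferative read-out. No supporting data explain this step.

The compounds shown leave open whether a benzyl group or a longer chain on the sulfur would keep the number of compound 2. On these data alone, whether acetyl would have a similar effect on the cores of compound 1 and compound 3 also remains unknown.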